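Aroyl to cyclopropylmethyl carbonyl on the shared core

The source may hold more compounds than are shown below. What is called first, only, known or untested is meant among the compounds shown, and "the series" means these compounds.

Three measured amides share the core of compound 1 `Cc1ccc(C(=O)N[C@@H](C(=O)N2CCC(c3ccc(Cl)cc3)CC2)C(C)C)cc1`. In an assay on THP-1 cells for displacement of a labelled ligand from C-C chemokine receptor type 1 (Homo sapiens) (on this read-out higher numbers stand for weaker inhibition and lower numbers for stronger inhibition), compound 1 gives 25 nM, the lowest of the three numbers. Compound 2 `CC[C@@H](C)[C@@H](NC(=O)c1ccccc1)C(=O)N1CCC(c2ccc(Cl)cc2)CC1` gives 45 nM in this assay, within the scatter of compound 1. Compound 3 `Cc1ccccc1C(=O)NC(CC(C)C)C(=O)N1CCC(c2ccc(Cl)cc2)CC1` gives 88 nM in this assay, beyond the scatter above compound 1. No pair among these differs in only one place, so no single step has been traced.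

Compound 4 `CC(C)[C@@H](NC(=O)CC1CC1)C(=O)N1CCC(c2ccc(Cl)cc2)CC1` has not been measured. Relative to compound 1 the change is cyclopropylmethyl in place of 4-methylphenyl on a carbonyl carbon. The aromatic ring on the carbonyl carbon is the part the measured compounds hold in common, so its loss is expected to weaken binding, a step of a 3.6-fold higher number from compound 1 to compound 4 (0.56 log units; beyond the scatter) beyond the scatter. Compound 4 is estimated at 90 nM, between 30 nM and 300 nM.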

Compound 4, half-maximal inhibitory concentration: 46 nM
Beside the measured number, compound 4's estimate is 2.0-fold (0.29 log units) above it, and the stated range covers the measured number.
By their numbers in this assay, from the lowest: compounds 1, 2, 4 and 3 (each within the scatter of the next, the first and the last beyond it).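

In this assay, among the compounds shown here, cyclopropylmethyl in place of 4-methylphenyl on a carbonyl carbon gives a 1.8-fold higher number from compound 1 to compound 4 (0.26 log units; within the scatter), the first single-place step. At this position the aromatic ring can therefore be exchanged for a three-membered non-aromatic ring with fewer heavy atoms without a change beyond the scatter. No available evidence bears on this result.

Going by these compounds, whether any ring is needed on this carbonyl carbon remains open. A plain butyl chain, or such a chain ending in an amine or a carboxylic acid, would address that.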